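From a Piperazine Chain to Dimethylamino

The source may hold more compounds than are shown below. What is called first, only, known or untested is meant among the compounds shown, and "the series" means these compounds.

Three compounds have been measured in a toxicity assay on HEK-293T cells (Homo sapiens) for cytotoxicity, read by MTT assay, with a stated time of 72 h; on this read-out lower numbers stand for stronger inhibition and higher numbers for weaker inhibition
- compound 1 `O=C1c2c[n+]([O-])c3ccccc3c2C(=O)c2c1c1ccccc1n2CCCCN1CCNCC1` gives 760 nM
- compound 2 `CN1CCN(CCCn2c3c(c4ccccc42)C(=O)c2c[n+]([O-])c4ccccc4c2C3=O)CC1` gives 170 nM
- compound 3 `CN1CCN(CCCCCCn2c3c(c4ccccc42)C(=O)c2c[n+]([O-])c4ccccc4c2C3=O)CC1` gives 5800 nM

Among the measured compounds shown here, compound 3 stands highest of the three, with 5800 nM as its value so far. For the measured compounds named here, compound 4 `CN(C)CCCCn1c2c(c3ccccc31)C(=O)c1c[n+]([O-])c3ccccc3c1C2=O` has no measurement yet. Its difference from compound 3 is dimethylamino in place of 2-(4-methylpiperazin-1-yl)ethyl on a saturated chain carbon, four bonds along the chain from an aromatic nitrogen and amounts to dimethylamino in place of 2-(4-methylpiperazin-1-yl)ethyl on a saturated chain carbon, four bonds along the chain from an aromatic nitrogen. Going by the values given here, no measured step makes this exact exchange. Among the compounds with values here, two steps bear on it indirectly, as both end at compound 3. The first is a 7.6-fold higher number from compound 1 to compound 3 (0.88 log units; beyond the scatter) and is modest, while the second is a 34-fold higher number from compound 2 to compound 3 (1.53 log units; beyond the scatter) and is large. A modest step to a lower number is therefore expected in this assay with compound 1 at 760 nM and compound 2 at 170 nM as the guides. The expected move is an 8.3-fold lower number from compound 3 to compound 4 (0.92 log units; beyond the scatter) on this estimate. For compound 4 the estimated value is 700 nM with an expected range from 170 nM to 3000 nM in this estimate.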

Compound 4, half-maximal inhibitory concentration: 520 nM
Estimate against measurement, compound 4: 1.3-fold (0.13 log units) above, within the range that was stated.
By their numbers in this assay, from the lowest: compound 2; then compounds 4 and 1 (each within the scatter of the next); then compound 3.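

In this assay, dimethylamino in place of 2-(4-methylpiperazin-1-yl)ethyl gives an 11-fold lower number from compound 3 to compound 4 (1.05 log units; beyond the scatter), showing that a low number at this place, on a saturated chain carbon, four bonds along the chain from an aromatic nitrogen, does not depend on a piperazine ring. Dimethylamino in place of piperazin-1-yl gives a 1.5-fold lower number from compound 1 to compound 4 (0.16 log units; within the scatter), so the two groups cannot be told apart here, while the exchange of 4-methylpiperazin-1-yl for (dimethylamino)methyl gives a 3.1-fold higher number from compound 2 to compound 4 (0.49 log units; beyond the scatter) and leaves compound 2 with the lowest number. Nothing measured here explains any of these shifts.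

The compounds shown leave open how dimethylamino behaves on a shorter or longer chain. They also leave open whether another amine at the chain end, such as pyrrolidine or morpholine, or a carboxylic acid there, would fall in the same range.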